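Trimming the amine substituent of compound 3 down to ethyl

This account rests on a few compounds, and the source may have more. Where it says the series, first, only, none or still open, it means among the compounds named here.

Of the compounds shown here, three built on a shared core have been measured in an assay on cell membranes for displacement of a labelled ligand from Sigma non-opioid intracellular receptor 1 (Cavia porcellus), read by scintillation counting; on this read-out lower numbers stand for stronger inhibition and higher numbers for weaker inhibition. Compound 1 `COc1cc2c(cc1C(C)NCCCc1ccccc1)C=CC(C)(C)O2` gives 11 nM. Going by the values given here, compound 2 `COc1ccc(CNC(C)c2cc3c(cc2OC)OC(C)(C)C=C3)cc1` gives 165 nM, and the step of a 15-fold higher number from compound 1 to compound 2 (1.18 log units; beyond the scatter) is the only single-point change measured so far. Compound 3 `COc1cc2c(cc1C(C)N[C@@H](C)c1ccccc1)C=CC(C)(C)O2` gives 805 nM, the highest of the three numbers, above both compound 2 and compound 1 by margins beyond the scatter.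

Compound 4 `CCNC(C)c1cc2c(cc1OC)OC(C)(C)C=C2` has not yet been measured. It differs from compound 3 by hydrogen in place of phenyl on a saturated chain carbon bound to an amine nitrogen and a saturated chain carbon. Among the compounds with values here, no measured step covers this change: the one measured step, from compound 1 to compound 2, swaps one aryl-bearing group for another on the amine side rather than removing the aryl ring altogether, so it offers only indirect guidance. What the three values do show is that the nitrogen substituent strongly governs the read-out, and that compound 3, the weakest, is the starting point here.

Compound 4 is therefore expected to sit further up, with an expected step of a 3.7-fold higher number from compound 3 to compound 4 (0.57 log units; beyond the scatter), since nothing measured suggests that removing the ring would recover binding. The estimate for compound 4 in this assay is 3000 nM, with a range from 600 nM to 15000 nM.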

Compound 4, inhibition constant: 83 nM
Beside the measured number, compound 4's estimate is 36-fold (1.56 log units) above it; measured number below the stated range.
By their numbers in this assay, from the lowest: compound 1; then compounds 4 and 2 (each within the scatter of the next); then compound 3.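

In this assay, taking the ring off shows that the phenyl on a saturated chain carbon bound to an amine nitrogen and a saturated chain carbon is not required for a low number: cutting 1-phenylethyl to ethyl gives a 9.7-fold lower number from compound 3 to compound 4 (0.99 log units; beyond the scatter). An aromatic ring on the amine side is likewise not required to match compound 2, since a 2.0-fold lower number from compound 2 to compound 4 (0.30 log units; within the scatter) lies within the scatter, with methyl in place of 4-methoxyphenyl. Removing a ring does not act the same way everywhere on this side, however: with hydrogen in place of benzyl on a saturated chain carbon, two bonds along the chain from an amine nitrogen, the change runs the other way, giving a 7.5-fold higher number from compound 1 to compound 4 (0.88 log units; beyond the scatter), so among these compounds compound 3 and compound 1 point in opposite directions.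

No measurement at hand accounts for either direction. The compounds shown leave open how a propyl chain or a plain primary amine in place of the ethyl group of compound 4 would read in this assay, and whether the opposite stereoisomer of compound 3 would read as compound 3 does.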